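Triazole substituent series, cytotoxicity on PC-3 cells

A few compounds are considered here, and "the series" means these few. Any claim that something is new, unique, unknown or untested is made for them only; others in the source may bear on it.

Measured compounds:
compound 1 `CCCCCCCc1cn(C(c2ccccc2)c2cc3cc(Br)ccc3nc2OC)nn1` 4.42%
compound 2 `COc1nc2ccc(Br)cc2cc1C(c1ccccc1)n1cc(-c2ccccc2)nn1` 5.97%
compound 3 `CCCCCc1cn(C(c2ccccc2)c2cc3cc(Br)ccc3nc2OC)nn1` 11.4%

In an ADME assay on PC-3 cells (Homo sapiens) for cytotoxicity, read by sulforhodamine B assay, with a stated time of 48 h, tested at 10 uM (a higher number here means more inhibition at the concentration tested (going by the name of the read-out), a lower number less inhibition), the three compounds differ only in the group on the triazole ring. Compound 3 stands at the upper edge of the three numbers, yet by a number 5.4 percentage points higher from compound 2 to compound 3 (within the scatter) and a number 7 percentage points higher from compound 1 to compound 3 (within the scatter), both within the scatter, so the three read as one level, and a number 1.6 percentage points higher from compound 1 to compound 2 (within the scatter) says the same.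

Compound 4 `COc1nc2ccc(Br)cc2cc1C(c1ccccc1)n1cc(CO)nn1` is the next member. It differs from compound 3 by hydroxy in place of butyl on a saturated chain carbon bound to an aromatic carbon. The steps that bear on this place are the two into compound 3 given above: swapping heptyl, phenyl or pentyl at the same position moved the read-out by amounts within the scatter. For the measured compounds named here, no measured compound carries a hydroxymethyl or any group with a hydrogen-bond donor at this place, so the step to compound 4 has no direct precedent. On the pattern of the three measured changes, the step of a number 2.4 percentage points lower from compound 3 to compound 4 (within the scatter) is expected to stay within the scatter.

Compound 4 is therefore estimated at 9%, with a range from 0% to 22% in this assay.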

Compound 4, a percentage reported as inhibition, at one concentration (the size of the read-out at that concentration, not a potency): 4.65%
Beside the measured number, compound 4's estimate is 4.4 percentage points above it; low and high end bracket the measured number.
By their numbers in this assay, from the lowest: compounds 1, 4, 2 and 3 (each within the scatter of the next).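

In this assay the steps read a number 6.8 percentage points lower from compound 3 to compound 4 (within the scatter) and a number 1.3 percentage points lower from compound 2 to compound 4 (within the scatter) and a number 0.2 percentage points higher from compound 1 to compound 4 (within the scatter) and so hydroxymethyl, which brings a hydrogen-bond donor to this place, stands at one level with the heptyl, pentyl and phenyl groups. Across these four compounds, the read-out therefore does not separate a group with a hydrogen-bond donor from groups without one, and the exchange of butyl for hydroxy on a saturated chain carbon bound to an aromatic carbon stays within the scatter. Nothing available gives a cause for this result.

As far as these compounds go, what remains open is whether any group at this place can move the read-out beyond the scatter, for instance an aminomethyl group or a carboxylic acid. The compounds shown also leave open whether this single level holds at other concentrations.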